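Aminothiazole acetamides: a fluorophenyl swap repeated on a bromophenyl core

The source may hold more compounds than are shown below. What is called first, only, known or untested is meant among the compounds shown, and "the series" means these compounds.

Measured so far in a functional assay on A549 cells (Homo sapiens) for cytotoxicity, read by MTT assay, with a stated time of 48 h; a higher number here means a weaker inhibitor, a lower number a stronger inhibitor:
compound 1 `Cc1ccc(-c2csc(NC(=O)COc3ccccc3C)n2)cc1` gives 50900 nM
compound 2 `Cc1ccc(-c2csc(NC(=O)COc3ccc(F)cc3F)n2)cc1` gives 13900 nM
compound 3 `Cc1ccccc1OCC(=O)Nc1nc(-c2ccc(Br)cc2)cs1` gives 50100 nM

Three compounds share an acetamide-linked aminothiazole core and differ at two places. Compound 1 and compound 2 differ by 2,4-difluorophenyl in place of 2-methylphenyl on an oxygen on a saturated carbon; this change made the step of a 3.7-fold lower number from compound 1 to compound 2 (0.56 log units; beyond the scatter). Compound 1 and compound 3 differ in their cores by bromo in place of methyl on an aromatic carbon; this change made the step of a 1.0-fold lower number from compound 1 to compound 3 (0.01 log units; within the scatter), so the two numbers cannot be told apart. Among the compounds with values here, of compound 2 and compound 3 no step is computed here; their two values simply show compound 2 with the lower number.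

Compound 4 `O=C(COc1ccc(F)cc1F)Nc1nc(-c2ccc(Br)cc2)cs1` is not yet measured. It differs from compound 3 by 2,4-difluorophenyl in place of 2-methylphenyl on an oxygen on a saturated carbon. The place line for this change reads word for word as it does for the change from compound 1 to compound 2, so it is the same change, now made on the core of compound 3 rather than on the core of compound 1. Among the compounds shown it occurs two times in all.

The expectation for compound 4 rests on one observation: the same change, made once, gave a 3.7-fold lower number from compound 1 to compound 2 (0.56 log units; beyond the scatter). Because a 1.0-fold lower number from compound 1 to compound 3 (0.01 log units; within the scatter) shows that the cores of compound 1 and compound 3 give values that sit within the scatter of each other, the step is expected to carry over in size, and compound 4 is expected to show a 3.6-fold lower number from compound 3 to compound 4 (0.55 log units; beyond the scatter) in this assay. With a single precedent, the range kept is wide. Compound 4 is estimated at 14000 nM, expected to fall between 5000 nM and 40000 nM in this assay.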

Compound 4, half-maximal inhibitory concentration: 58800 nM
Estimate against measurement, compound 4: 4.2-fold (0.62 log units) below; measured number above the stated range.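

On the core of compound 3, the change from 2-methylphenyl to 2,4-difluorophenyl gave a 1.2-fold higher number from compound 3 to compound 4 (0.07 log units; within the scatter) in this assay, so the gain seen on the core of compound 1 did not carry over, and the size of this step differed between the two cores: the same change on two cores in this assay, a 3.7-fold lower number (0.56 log units; beyond the scatter) from compound 1 to compound 2 and a 1.2-fold higher number (0.07 log units; within the scatter) from compound 3 to compound 4, 4.3-fold (0.63 log units) apart, beyond the scatter of two such steps

Read the other way, bromo in place of methyl made no difference with 2-methylphenyl in the molecule but gave a 4.2-fold higher number from compound 2 to compound 4 (0.63 log units; beyond the scatter) with 2,4-difluorophenyl present, so the two changes do not add up independently in these four compounds: the same change on two cores in this assay, a 1.0-fold lower number (0.01 log units; within the scatter) from compound 1 to compound 3 and a 4.2-fold higher number (0.63 log units; beyond the scatter) from compound 2 to compound 4, 4.3-fold (0.63 log units) apart, beyond the scatter of two such steps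

This shows that a step measured on one core was not a safe guide to the other here, but it rests on one pair of cores and one pair of groups, and it does not show why the steps differ or that such a mismatch is general across the series.

The compounds shown leave open whether the same dependence on the core would appear with a chloro or a methoxy group in place of the bromo or methyl on the aromatic carbon. They also leave open how a 4-fluorophenyl or an unsubstituted phenyl on the oxygen would behave on either core.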